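From Bromo to Trifluoromethyl: A Small Step Expected

The source may hold more compounds than are shown below. What is called first, only, known or untested is meant among the compounds shown, and "the series" means these compounds.

In an ADME assay on Jurkat cells (Homo sapiens) for cytotoxicity, read by trypan blue exclusion, with a stated time of 24 h (a higher number here means a weaker inhibitor, a lower number a stronger inhibitor), compound 3 (`N#C[Se]Cc1ccc(Br)cc1`) gives 12700 nM as its value, within the usual scatter of compound 2 (`N#C[Se]Cc1cccc([N+](=O)[O-])c1`) at 12200 nM and of compound 1 (`N#C[Se]Cc1ccc([N+](=O)[O-])cc1`) at 6860 nM as well. The next structure, compound 4 (`N#C[Se]Cc1ccc(C(F)(F)F)cc1`), has trifluoromethyl in place of bromo on an aromatic carbon. For the measured compounds named here, only one measured step swaps one group for another in this way, and it stays inside the scatter. With only a 1.9-fold higher number from compound 1 to compound 3 (0.27 log units; within the scatter) to go on, for bromo in place of nitro, no change beyond the scatter is expected in this assay here. An estimated 1.3-fold lower number from compound 3 to compound 4 (0.10 log units; within the scatter) is expected. For compound 4 the expected value is 10000 nM within an estimated range of 5000 nM to 20000 nM overall.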

Compound 4, half-maximal inhibitory concentration: 7310 nM
Compound 4: middle estimate off by 1.4-fold (0.14 log units), on the high side; the measured number falls inside the stated range.
By their numbers in this assay, from the lowest: compounds 1, 4, 2 and 3 (each within the scatter of the next).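

At this position, in this assay, trifluoromethyl in place of bromo stays within the scatter (a 1.7-fold lower number from compound 3 to compound 4 (0.24 log units; within the scatter)), and so does trifluoromethyl in place of nitro (a 1.1-fold higher number from compound 1 to compound 4 (0.03 log units; within the scatter)). Bromo, nitro and trifluoromethyl at this one place are now all within the scatter of one another, even though the change from bromo takes the group from 1 heavy atom to 4 heavy atoms. Nothing measured here explains this result. As far as these compounds go, whether an amine, a carboxylic acid or a longer chain at this place would stay within the same range remains open.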